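Adding a Hydroxy Group to Compound 1

The source may hold more compounds than are shown below. What is called first, only, known or untested is meant among the compounds shown, and "the series" means these compounds.

Measured in a functional assay on OVCAR-5 cells (Homo sapiens) for inhibition (on this read-out lower numbers stand for stronger inhibition of growth and higher numbers for weaker inhibition of growth), so far
Compound 1 `COc1ccc(-n2cnnc2-c2cc(OC)c(OC)c(OC)c2)cc1` gives 3800 nM
Compound 2 `COc1cc(-c2nncn2-c2ccc(N(C)C)cc2)cc(OC)c1OC` gives 4270 nM

Compound 1 has a single measured neighbour, and the step of a 1.1-fold higher number from compound 1 to compound 2 (0.05 log units; within the scatter) shows no real difference. Compound 3 `COc1ccc(-n2cnnc2-c2cc(OC)c(OC)c(OC)c2)cc1O` is compound 1 with one change hydroxy in place of hydrogen on an aromatic carbon and has not yet been measured. The measured step replaces the methoxy group, whereas this change puts hydroxy in place of hydrogen, so it says little about size. Going by the values given here, no measured step covers this change, so a lower number in this assay is only a cautious expectation. The expected step is a 19-fold lower number from compound 1 to compound 3 (1.28 log units; beyond the scatter) and remains very uncertain. For compound 3 the estimated value is 200 nM (expected range 15 nM to 4000 nM) in this read-out.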

Compound 3, concentration for 50% growth inhibition: 1950 nM
The estimate for compound 3 lay 9.8-fold (0.99 log units) below the measured number, and the stated range covers the measured number.
By their numbers in this assay, from the lowest: compounds 3, 1 and 2 (each within the scatter of the next, the first and the last beyond it).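

Hydroxy in place of hydrogen on an aromatic carbon, ortho to a methoxy group, gives a 1.9-fold lower number from compound 1 to compound 3 (0.29 log units; within the scatter) in this assay. This position therefore takes a hydroxy group with no clear gain or loss, so changing a ring hydrogen, like replacing the methoxy group earlier, makes no real difference here. No available evidence bears on this result.

Still open, from the compounds shown here alone, is whether an amine or a carboxylic acid on this same carbon would shift the number beyond the scatter. Also open, going by these compounds, is whether hydroxy would behave the same way on compound 2.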